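The source may report more compounds than this note shows. Statements on the series, on what has been measured and on what is new or still open speak of the compounds shown alone.

Measured in an ADME assay on microsomes from liver (Mus musculus) for metabolic stability, read by LC-MS, with a stated time of 60 min, tested at 500 uM; a higher number here means that more of the compound is left, a lower number that less of the compound is left:
Compound 1 `COc1cc2c(cc1OC)CN(c1cccnc1)CC2`: 0.2%
Compound 2 `COc1cc2c(cc1OC)CN(c1cc(C(F)(F)F)cc(C(F)(F)F)c1)CC2`: 26.9%

Compound 1 stands lowest of these two, and compound 2 lies higher, beyond the scatter. Compound 3 `COc1cc2c(cc1OC)CN(c1ccccn1)CC2` carries pyridin-2-yl in place of pyridin-3-yl on an amine nitrogen in a ring. Within the data shown here, no measured pair shows what such a swap does in this assay. With compound 1 at 0.2%, little room remains downward, so a small upward step, probably within the scatter, is expected. The estimated change is a number 4.8 percentage points higher from compound 1 to compound 3 (within the scatter). For compound 3 the expected value is 5%, with an estimated range from 0.5% to 20%.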

Compound 3, percent of the compound remaining: 0.2%
Beside the measured number, compound 3's estimate is 4.8 percentage points above it; the measured number lies below the stated range.
By their numbers in this assay, from the lowest: compounds 1 and 3 (each within the scatter of the next); then compound 2.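

In this assay, among these compounds, pyridin-2-yl in place of pyridin-3-yl on an amine nitrogen in a ring gives no change at the digits printed from compound 1 to compound 3 (within the scatter), the first one-place comparison at this position. Moving the pyridine attachment therefore does not lift the compound off the bottom of the read-out, where any further loss could hardly show. Nothing at hand offers a reason for this result.

Left open is whether pyridin-4-yl or a phenyl ring with a single trifluoromethyl at this nitrogen would leave more compound. As far as these compounds go, the effect of replacing the two methoxy groups on the shared core also remains open.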